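A few compounds are considered here, and "the series" means these few. Any claim that something is new, unique, unknown or untested is made for them only; others in the source may bear on it.

Compound 1 `CC(C)CCn1cc(/C=C/C(=O)CC(=O)C(=O)O)c2ccccc21`: 16.3 uM
Compound 2 `C=C(C)Cn1cc(/C=C/C(=O)CC(=O)C(=O)O)c2ccccc21`: 2.5 uM
Compound 3 `COc1ccc(Cn2cc(/C=C/C(=O)CC(=O)C(=O)O)c3ccccc32)cc1`: 10 uM

These three compounds share one core and differ only in the group on a saturated chain carbon bound to an aromatic nitrogen. In an assay on isolated protein for inhibition of DNA nucleotidylexotransferase (Homo sapiens), read by scintillation counting, with a stated time of 10 min (a higher number here means a weaker inhibitor, a lower number a stronger inhibitor), compound 3 gives 10 uM. Among the three numbers compound 3 stands between the others: compound 1 sits within the scatter of it, while compound 2 lies beyond the scatter, on the side of stronger inhibition.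

Compound 4 `O=C(/C=C/c1cn(CC(=O)N2CCOCC2)c2ccccc12)CC(=O)C(=O)O` carries the change ((morpholin-4-yl)carbonyl in place of 4-methoxyphenyl on a saturated chain carbon bound to an aromatic nitrogen). Among the measured compounds shown here, no measured step introduces a (morpholin-4-yl)carbonyl group, so the expectation rests on how far this position has moved the number at all. The step of a 1.6-fold lower number from compound 1 to compound 3 (0.21 log units; within the scatter) was within the scatter, whereas a 4.0-fold higher number from compound 2 to compound 3 (0.60 log units; beyond the scatter) and a 6.5-fold lower number from compound 1 to compound 2 (0.81 log units; beyond the scatter) were each modest. Changes at this position have therefore shifted the number modestly in either direction, and nothing in the three values points to a direction for the new group. The estimate for compound 4 is therefore a step of no change at the digits printed from compound 3 to compound 4 (within the scatter), meaning no confident shift beyond the scatter but with a wide range. Compound 4 is expected to give about 10 uM in this assay, with a likely range from 3 uM to 40 uM.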

Compound 4, concentration for 50% inhibition: 24 uM
Estimate against measurement, compound 4: 2.4-fold (0.38 log units) below, and the stated range covers the measured number.
By their numbers in this assay, from the lowest: compound 2; then compounds 3, 1 and 4 (each within the scatter of the next, the first and the last beyond it).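

In this assay, (morpholin-4-yl)carbonyl in place of 4-methoxyphenyl gives a 2.4-fold higher number from compound 3 to compound 4 (0.38 log units; beyond the scatter), so this position can hold a non-aromatic ring with two hetero atoms and still give a measurable inhibitor, though with a modestly higher number than compound 3. The new group also widens the span seen at this position, with a 9.6-fold higher number from compound 2 to compound 4 (0.98 log units; beyond the scatter) being the largest step among the four compounds, while a 1.5-fold higher number from compound 1 to compound 4 (0.17 log units; within the scatter) means that the new group and isobutyl cannot be told apart in this assay, despite their different structures. Compound 2 remains the strongest of the four, and no measured evidence bears on why these groups rank as they do.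

The compounds shown leave open whether the number follows the carbonyl or the ring oxygen of the new group, a question that a (piperidin-1-yl)carbonyl group could help to separate. They also leave open how a carboxylic acid, an amine or a longer alkenyl chain in this place would compare with the 1-methylethenyl group of compound 2.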